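Compound 3 to Compound 4: an Expected Limit

The compounds below may be only part of what the source reports. "The series", "measured", "known", "first", "only" and "open" are said of these compounds alone.

Compound 3 `COc1cccc(/C=C/C(=O)c2sc(Nc3cccc(C)c3)nc2C)c1` belongs to a small group of compounds tested in a functional assay on BGC-823 cells (Homo sapiens) for cytotoxicity, read by MTT assay; a lower number here means a stronger inhibitor, a higher number a weaker inhibitor. In this assay compound 3 gives > 25000 nM, which is a limit of the assay and not a number. Its relatives compound 1 `COc1ccc(/C=C/C(=O)c2sc(Nc3ccc(Cl)cc3)nc2C)cc1` and compound 2 `Cc1nc(Nc2ccc(Cl)cc2)sc1C(=O)/C=C/c1ccccc1` share the same core. In this assay compound 1 gives > 25000 nM, again only a limit. In this assay compound 2 gives > 25000 nM, also a limit. All three measured values thus sit at the limit of > 25000 nM in this assay, at which 3 of the 3 values shown sit, and compound 3 stands level with its two relatives as far as the numbers can tell. Going by the values given here, the one step between them, a step that the two limits leave unreadable from compound 1 to compound 2, is accordingly of unknown size. Compound 4 `COc1cccc(/C=C/C(=O)c2sc(Nc3ccc(Cl)cc3)nc2C)c1` differs from compound 3 by 4-chlorophenyl in place of 3-methylphenyl on a nitrogen on an aromatic ring. Among the compounds with values here, no measured step covers this change; the only step on record, from compound 1 to compound 2, concerns another place and cannot be read. With every measured value at the limit, the expected step is a step that the limit leaves unreadable from compound 3 to compound 4, nothing beyond the scatter. Compound 4 is therefore estimated to give about 30000 nM in this assay, between 12000 nM and 100000 nM, most likely reported once more as a limit.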

Compound 4, half-maximal inhibitory concentration: > 25000 nM
Compound 4: only a limit was reported; the forecaster's own chance of this, stated with the estimate: 80%; the middle value does not contradict the limit.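

No step can be read from compound 4 to compound 1, compound 2 or compound 3, because every value in this assay is only a limit of the assay: the limit of > 25000 nM in this assay, at which 4 of the 4 values shown sit.

The compounds shown leave open whether placing 4-chlorophenyl for 3-methylphenyl, or moving or removing the methoxy, changes cytotoxicity at all.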